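A few compounds are considered here, and "the series" means these few. Any claim that something is new, unique, unknown or untested is made for them only; others in the source may bear on it.

Measured compounds:
- compound 1 `O=S(=O)(NCCCNCc1ccc(Cl)c(C(F)(F)F)c1)c1cc(C(F)(F)F)cc(C(F)(F)F)c1`: 7400 nM
- compound 2 `CN(CCCNS(=O)(=O)c1cc(C(F)(F)F)cc(C(F)(F)F)c1)Cc1ccccc1`: 33000 nM

Series notes. In a functional assay on MIA PaCa-2 cells (Homo sapiens) for inhibition, read by MTT assay, with a stated time of 72 h (a higher number here means a weaker inhibitor of growth, a lower number a stronger inhibitor of growth), compound 2 gives 33000 nM, the highest number of the two measured; the nearest is compound 1, which gives 7400 nM, a gap that lies beyond the scatter. Among the measured compounds shown here, compound 1 and compound 2 differ in two places at once, on the amine nitrogen and on the benzyl ring, so no single step between them can be read.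

Compound 3 `O=S(=O)(NCCCNCc1ccccc1)c1cc(C(F)(F)F)cc(C(F)(F)F)c1` is not yet measured in this assay. It differs from compound 2 by hydrogen in place of methyl on an amine nitrogen. Compound 3 thus shares the secondary amine of compound 1 but the plain benzyl group of compound 2.

For the measured compounds named here, with no measured pair isolating this change, the step is expected to be modest: a lower number than compound 2 is judged somewhat more likely than a higher one, but a step within the scatter is also plausible. Compound 3 is therefore expected at 15000 nM, with a range of 5000 nM to 45000 nM, implying an expected step of a 2.2-fold lower number from compound 2 to compound 3 (0.34 log units; beyond the scatter).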

Compound 3, concentration for 50% growth inhibition: 11000 nM
Compound 3: middle estimate off by 1.4-fold (0.13 log units), on the high side; the range from low to high includes it.
By their numbers in this assay, from the lowest: compounds 1 and 3 (each within the scatter of the next); then compound 2.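

In this assay, hydrogen in place of methyl on an amine nitrogen now has a reading of its own, with the plain benzyl group held constant: a 3.0-fold lower number from compound 2 to compound 3 (0.48 log units; beyond the scatter) is the step, so this nitrogen is a position where a single methyl is enough to shift the number beyond the scatter. On the ring side, phenyl in place of 4-chloro-3-(trifluoromethyl)phenyl on a saturated chain carbon bound to an amine nitrogen gives a 1.5-fold higher number from compound 1 to compound 3 (0.17 log units; within the scatter) and so does not separate the two compounds, which means that among these three compounds only the nitrogen change gives a step beyond the scatter. No measurement at hand bears on the reason for either step.

Going by these compounds, the methyl step is known only with the plain benzyl group, so its size with the 4-chloro-3-(trifluoromethyl)phenyl ring remains open. Also open, on these data alone, are how an ethyl group or a carbonyl on that nitrogen would read, and whether a single chloro or a single trifluoromethyl on the ring would behave as the pair of them does.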